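The compounds below may be only part of what the source reports. "The series", "measured", "known", "first", "only" and "open" are said of these compounds alone.

Four chalcone-type compounds built on a common dinitro(trifluoromethyl)phenoxy core were examined for antiproliferative activity. Compound 1 `COc1ccc(C(=O)/C=C/c2cccc(Br)c2Oc2c([N+](=O)[O-])cc(C(F)(F)F)cc2[N+](=O)[O-])cc1` and compound 2 `COc1ccc(C(=O)/C=C/c2cccc(Cl)c2Oc2c([N+](=O)[O-])cc(C(F)(F)F)cc2[N+](=O)[O-])cc1` carry a single halogen on the ring that bears the enone, and differ only there: bromo in place of chloro on an aromatic carbon. In a functional assay on A549 cells (Homo sapiens) for antiproliferative activity, read by MTT assay, with a stated time of 48 h (on this read-out lower numbers stand for stronger inhibition and higher numbers for weaker inhibition), compound 2 gives 11.5 ug/mL, while compound 1 gives 12.7 ug/mL, so the exchange produced a 1.1-fold higher number from compound 2 to compound 1 (0.04 log units; within the scatter). Compound 3 `O=C(/C=C/c1cc(Br)cc(Br)c1Oc1c([N+](=O)[O-])cc(C(F)(F)F)cc1[N+](=O)[O-])c1ccc(Cl)cc1` has a different core from compound 2, and that difference is not broken down here; in this assay compound 3 gives 19.4 ug/mL, which stands within the scatter of both compound 1 and compound 2, so no order among the three can be stated.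

Compound 4 `O=C(/C=C/c1cc(Br)cc(Br)c1Oc1c([N+](=O)[O-])cc(C(F)(F)F)cc1[N+](=O)[O-])c1ccc(Br)cc1` has not yet been measured. It is related to compound 3 by bromo in place of chloro on an aromatic carbon. Going by the values given here, this is the same kind of change as the one from compound 2 to compound 1, but not the same change: there the place was ortho to a large group and meta to a 2-((4-methoxyphenyl)carbonyl)ethenyl group, here it is para to a large group. Because the earlier exchange gave a 1.1-fold higher number from compound 2 to compound 1 (0.04 log units; within the scatter), a step of comparable size is expected here, namely a 1.0-fold higher number from compound 3 to compound 4 (0.01 log units; within the scatter). On that basis compound 4 is estimated to give 20 ug/mL in this assay, expected to lie between 10 ug/mL and 40 ug/mL.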

Compound 4, half-maximal inhibitory concentration: 16.8 ug/mL
Compound 4: the middle estimate sits 1.2-fold (0.08 log units) above what was measured; measured number inside the range.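

In this assay, bromo in place of chloro on the 4-chlorophenyl group gave a 1.2-fold lower number from compound 3 to compound 4 (0.06 log units; within the scatter), and set beside the earlier exchange on the other core, the result reads: the same change on two cores in this assay, a 1.1-fold higher number (0.04 log units; within the scatter) from compound 2 to compound 1 and a 1.2-fold lower number (0.06 log units; within the scatter) from compound 3 to compound 4, 1.3-fold (0.11 log units) apart, within the scatter of two such steps On the two cores shown, this exchange therefore stayed within the scatter each time, and the two steps cannot be told apart, which fits the change carrying from one core to the other with little consequence for this read-out. Going by these compounds alone, this does not show that chloro and bromo can be exchanged freely across the series: there are only two pairs, the exchange sits at a different place in each, both steps are too small to give a direction, and only one cell line is covered.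

The compounds shown leave open whether a larger step would appear with a different replacement at these places, such as a hydrogen, an amine or a carboxylic acid in place of the halogen. They also do not break down the other differences between the core of compound 2 and the core of compound 3, so what each of those differences contributes on its own remains unresolved.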